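The compounds below may be only part of what the source reports. "The series", "measured", "known", "first", "only" and "open" are said of these compounds alone.

In a functional assay on MCF7 cells (Homo sapiens) for inhibition (on this read-out higher numbers stand for weaker inhibition and lower numbers for stronger inhibition), compound 1 `CCN(C(=O)CC(CC(=O)NCCN1CCCCC1)c1ccc(Cl)cc1)C1Cc2ccccc2C1` gives 16500 nM and compound 2 `CCN(CC)CCNC(=O)CC(CC(=O)N(CC)C1Cc2ccccc2C1)c1ccc(Cl)cc1` gives 23000 nM. Among the compounds with values here, these are the only two numbers so far, and they lie within the usual scatter of each other. Compound 3 `CCNCCNC(=O)CC(CC(=O)N(CC)C1Cc2ccccc2C1)c1ccc(Cl)cc1` differs from compound 2 by hydrogen in place of ethyl on an amine nitrogen, with hydrogen in place of ethyl on an amine nitrogen. Within the data shown here, the one measured step that bears on this, also a change at that amine, is a 1.4-fold higher number from compound 1 to compound 2 (0.14 log units; within the scatter). A similarly small change is therefore expected in this assay, namely a 1.2-fold lower number from compound 2 to compound 3 (0.06 log units; within the scatter), none beyond the scatter. The value estimated for compound 3 is 20000 nM, with a range from 9000 nM to 45000 nM.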

Compound 3, half-maximal inhibitory concentration: 14400 nM
Estimate against measurement, compound 3: 1.4-fold (0.14 log units) above; measured number inside the range.
By their numbers in this assay, from the lowest: compounds 3, 1 and 2 (each within the scatter of the next).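

In this assay, hydrogen in place of ethyl on an amine nitrogen gives a 1.6-fold lower number from compound 2 to compound 3 (0.20 log units; within the scatter), and ethylamino in place of piperidin-1-yl gives a 1.1-fold lower number from compound 1 to compound 3 (0.06 log units; within the scatter). The ethylamino, diethylamino and piperidin-1-yl forms therefore cannot be told apart here, even with a hydrogen now on that nitrogen. No available evidence bears on why. Still open, as far as these compounds go, is whether a primary amine, with no ethyl left, or a carboxylic acid in place of the amine would also stay within the scatter. A longer chain leading to the amine is equally untested among these compounds.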